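The source may hold more compounds than are shown below. What is called first, only, known or untested is meant among the compounds shown, and "the series" means these compounds.

Measured so far in a functional assay on the whole organism for inhibition, with Mus musculus as the target, in the writhing test, with stated times of 3 days and 20 min, at a dose of 30 mg/kg by the oral route; a higher number here means more inhibition at the dose given (going by the name of the read-out), a lower number less inhibition:
compound 1, `Cc1ccc(-c2cc(C)n(S(=O)(=O)Oc3ccccc3)n2)cc1`: 50.7%
compound 2, `Cc1ccc(-c2cc(C)n(S(=O)(=O)Oc3ccc(I)cc3)n2)cc1`: 17.2%

Going by the values given here, compound 1 stands highest of the two numbers in this assay; its nearest neighbour is compound 2, and the single measured step is a number 33.5 percentage points lower from compound 1 to compound 2 (beyond the scatter), brought about by iodo in place of hydrogen on an aromatic carbon.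

Compound 3, `Cc1cc(-c2ccco2)nn1S(=O)(=O)Oc1ccccc1`, differs from compound 1 by furan-2-yl in place of 4-methylphenyl on an aromatic carbon of the shared core. Among the compounds with values here, no measured step touches this position; the one step known changes the aryl of the sulfonate ester, not the group on the core, so it bears on compound 3 only by showing that a single aromatic exchange can move the read-out well beyond the scatter. For compound 3 a lowering is expected, a number 15.7 percentage points lower from compound 1 to compound 3 (beyond the scatter), with wide uncertainty. The estimate for compound 3 in this assay is 35%, between 10% and 62%.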

Compound 3, a percentage reported as inhibition, in the whole organism at one dose (the size of the read-out at that dose, not a potency): 42.5%
For compound 3 the middle estimate is 7.5 percentage points below the measured one; low and high end bracket the measured number.
By their numbers in this assay, from the lowest: compound 2; then compounds 3 and 1 (each within the scatter of the next).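

In this assay, going by these compounds alone, the first exchange at this position on the shared core gives a number 8.2 percentage points lower from compound 1 to compound 3 (within the scatter), so furan-2-yl in place of 4-methylphenyl gives a read-out that cannot be told apart from that of compound 1. At this position, then, a five-membered aromatic ring with one hetero atom can replace the six-membered carbon ring with no difference that stands clear of the scatter. Nothing measured on these compounds offers an account of this result.

Going by these compounds, what an amine, a carboxylic acid or a longer chain would do on this aromatic carbon stays open, as does whether any aromatic ring is needed here at all. Also open, on these data alone, is whether furan-2-yl would give a similar read-out when combined with the iodo group of compound 2.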